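Swapping cyclohexylamino for butoxy: expected cytotoxicity of compound 4

The source may hold more compounds than are shown below. What is called first, only, known or untested is meant among the compounds shown, and "the series" means these compounds.

Compound 1 `Nc1nc(NC2CCCCC2)c2ncn(/C=C3/CC3(CO)CO)c2n1`: > 24000 nM
Compound 2 `CN(C)c1nc(N)nc2c1ncn2/C=C1/CC1(CO)CO`: > 24000 nM
Compound 3 `CC(C)Nc1nc(N)nc2c1ncn2/C=C1/CC1(CO)CO`: > 24000 nM

In an ADME assay on Akata cells (Homo sapiens) for cytotoxicity, with a stated time of 7 days (on this read-out lower numbers stand for higher toxicity in this test and higher numbers for lower toxicity in this test), compound 1 gives > 24000 nM, which is a limit of the assay rather than a number. Compound 2 likewise gives > 24000 nM, a limit. Compound 3 gives > 24000 nM, also a limit. The steps a step that the two limits leave unreadable from compound 1 to compound 2, a step that the two limits leave unreadable from compound 1 to compound 3 and a step that the two limits leave unreadable from compound 2 to compound 3 therefore cannot be sized, because of the limit of > 24000 nM in this assay, at which 3 of the 3 values shown sit.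

Compound 4 `CCCCOc1nc(N)nc2c1ncn2/C=C1/CC1(CO)CO` differs from compound 1 by butoxy in place of cyclohexylamino on an aromatic carbon. For the measured compounds named here, none of the measured steps touches butoxy, and all of them are hidden by the limit, so no step beyond the scatter can be read from them. Given the three limits, compound 4 is expected to sit at the limit again, a step that the limit leaves unreadable from compound 1 to compound 4. The estimate for compound 4 is 30000 nM, expected between 12000 nM and 120000 nM.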

Compound 4, half-maximal cytotoxic concentration: > 20000 nM
Compound 4 ended at the assay's limit; the forecaster's own chance of this, stated with the estimate: 85%; the middle value is on the limit's open side.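

For the compounds shown here, compounds 1, 2, 3 and 4 all give limits of the assay rather than numbers, and no step from compound 1, 2 or 3 to compound 4 can be read. On these data alone, whether any of these groups on the shared core changes cytotoxicity at all stays open.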